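Swapping an alkyne for a fluorophenyl on the shared core

The compounds below may be only part of what the source reports. "The series", "measured", "known", "first", "only" and "open" are said of these compounds alone.

In an ADME assay (liver) for metabolic stability, with Liver microsome (Rattus norvegicus) as the target, using microsomes and NADPH, with a stated time of 30 min, tested at 1 uM (a higher number here means faster removal of the compound, a lower number slower removal), compound 2 `CC(C)(O)C#Cc1cc(C(O)(C(F)(F)F)C(F)(F)F)cnc1N1CCN(S(=O)(=O)c2ccc(N)nc2)CC1` gives 16 mL.min-1.g-1, the lowest of the three numbers measured here. Compound 1 `COCC#Cc1cc(C(O)(C(F)(F)F)C(F)(F)F)cnc1N1CCN(S(=O)(=O)c2ccc(N)nc2)CC1` gives 399 mL.min-1.g-1 and compound 3 `CCn1cc(-c2cc(C(O)(C(F)(F)F)C(F)(F)F)cnc2N2CCN(S(=O)(=O)c3ccc(N)nc3)CC2)cn1` gives 194 mL.min-1.g-1 in this assay. The unmeasured compound 4 `Nc1ccc(S(=O)(=O)N2CCN(c3ncc(C(O)(C(F)(F)F)C(F)(F)F)cc3-c3cccc(F)c3)CC2)cn1` differs from compound 2 as follows: 3-fluorophenyl in place of 3-hydroxy-3-methylbut-1-yn-1-yl on an aromatic carbon. The change sits on an aromatic carbon of a six-membered aromatic ring with one nitrogen, two atoms from the ring nitrogen. The step that bears most directly on it is a 12-fold higher number from compound 2 to compound 3 (1.08 log units; beyond the scatter), where the same 3-hydroxy-3-methylbut-1-yn-1-yl group was also exchanged for an aromatic ring on the same position; the step of a 25-fold lower number from compound 1 to compound 2 (1.40 log units; beyond the scatter) shows the same group arriving with a large fall. For compound 4 a large rise is therefore expected, with the 3-fluorophenyl compound 4 estimated at 300 mL.min-1.g-1 (range 120 mL.min-1.g-1 to 750 mL.min-1.g-1), which means an expected step of a 19-fold higher number from compound 2 to compound 4 (1.27 log units; beyond the scatter).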

Compound 4, intrinsic clearance in microsomes: 52 mL.min-1.g-1
Estimate against measurement, compound 4: 5.8-fold (0.76 log units) above, and the stated range ends above it.
By their numbers in this assay, from the lowest: compound 2; then compound 4; then compound 3; then compound 1.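

Putting 3-fluorophenyl in place of 3-hydroxy-3-methylbut-1-yn-1-yl on this aromatic carbon gives only a modest rise in this assay, with a 3.3-fold higher number from compound 2 to compound 4 (0.51 log units; beyond the scatter), against a 12-fold higher number from compound 2 to compound 3 (1.08 log units; beyond the scatter) for the 1-ethyl-1H-pyrazol-4-yl group, so an aromatic ring at this position does not always bring a large rise. The identity of the ring counts as well, with a 3.7-fold lower number from compound 3 to compound 4 (0.57 log units; beyond the scatter), and the 3-fluorophenyl group also lies clearly under the 3-methoxyprop-1-yn-1-yl group, with a 7.7-fold lower number from compound 1 to compound 4 (0.88 log units; beyond the scatter). Compound 2 still has the lowest number of the four, and neither aromatic ring reaches it.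

Nothing shown here accounts for these differences. On these data alone, it also stays open where an unsubstituted phenyl ring or a 3-aminophenyl group would fall relative to compound 2 and compound 4.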